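Compound 3 to compound 4: the amide nitrogen substituent

This account rests on a few compounds, and the source may have more. Where it says the series, first, only, none or still open, it means among the compounds named here.

In a functional assay on A549 cells (Homo sapiens) for inhibition, read by MTT assay, with a stated time of 48 h (on this read-out lower numbers stand for stronger inhibition and higher numbers for weaker inhibition), compound 3 `COc1cccc(NC(=O)/C=C/c2coc3cc(OC)ccc3c2=O)c1` gives 12800 nM, the lowest number among the measured values. Compound 2 `COc1ccc2c(=O)c(/C=C/C(=O)Nc3ccccc3)coc2c1` gives 51000 nM. Within the data shown here, the one measured step, with methoxy in place of hydrogen on an aromatic carbon, is a 4.0-fold lower number from compound 2 to compound 3 (0.60 log units; beyond the scatter). Among the measured compounds shown here, compound 1 `COc1ccc(CNC(=O)/C=C/c2coc3cc(O)ccc3c2=O)cc1`, the only measured compound bearing 4-methoxybenzyl, reads > 100000 nM, which is a limit and not a number. Compound 4 `COc1ccc(CNC(=O)/C=C/c2coc3cc(OC)ccc3c2=O)cc1` differs from compound 3 by 4-methoxybenzyl in place of 3-methoxyphenyl on an amide-type nitrogen, with 4-methoxybenzyl in place of 3-methoxyphenyl on an amide-type nitrogen. For the measured compounds named here, no measured step covers this change directly, so a modest shift to a higher number is expected, on the scale of a 4.0-fold lower number from compound 2 to compound 3 (0.60 log units; beyond the scatter). The estimated change is a 2.7-fold higher number from compound 3 to compound 4 (0.44 log units; beyond the scatter). For compound 4 the estimated value is 35000 nM, with an expected range of 11000 nM to 100000 nM.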

Compound 4, half-maximal inhibitory concentration: 22500 nM
For compound 4 the middle estimate is 1.6-fold (0.19 log units) above the measured one, and the stated range covers the measured number.
By their numbers in this assay, from the lowest: compounds 3 and 4 (each within the scatter of the next); then compound 2. At a limit, above all of these: compound 1.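

Putting 4-methoxybenzyl in place of 3-methoxyphenyl on the amide-type nitrogen gives a 1.8-fold higher number from compound 3 to compound 4 (0.24 log units; within the scatter), so this position does not tell these two groups apart. Against phenyl at the same nitrogen, the 4-methoxybenzyl group gives a 2.3-fold lower number from compound 2 to compound 4 (0.36 log units; beyond the scatter), while methyl in place of hydrogen on the oxygen on the aromatic ring, with 4-methoxybenzyl held fixed, gives an at least 4.4-fold lower number from compound 1 to compound 4 (0.64 log units; beyond the scatter). That last step starts from a limit for compound 1, not a number: the limit of > 100000 nM in this assay, at which 1 of the 4 values shown sits.

Still open, from the compounds shown here alone, is whether an amine, a carboxylic acid or a longer chain in place of 4-methoxybenzyl on the amide-type nitrogen would move the number.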